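A Chloro to Bromo Swap on Compound 2

A few compounds are considered here, and "the series" means these few. Any claim that something is new, unique, unknown or untested is made for them only; others in the source may bear on it.

In a functional assay on Jurkat cells (Homo sapiens) for cytotoxicity, read by luminescence and CellTiter-Glo, with a stated time of 3 days (a higher number here means a weaker inhibitor, a lower number a stronger inhibitor), three compounds have results so far. Compound 1 `O=C(Nc1ccc(OC(F)(F)F)c(Cl)c1)c1cc(F)ccc1O` reads 700 nM and compound 3 `O=C(Nc1cc(C(F)(F)F)cc(C(F)(F)F)c1)c1cc(Br)c(F)cc1O` reads 700 nM on this scale. Compound 2 `O=C(Nc1ccc(C(F)(F)F)cc1)c1cc(Cl)c(-c2ccccc2)cc1O` reads 1160 nM and so lies within the usual scatter of both others, which means the three cannot be ranked. Among the compounds with values here, they differ from one another in several places at once, so no measured pair shows the effect of a single change.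

Compound 4 `O=C(Nc1ccc(C(F)(F)F)cc1)c1cc(Br)c(-c2ccccc2)cc1O` has not been measured yet. It carries bromo in place of chloro on an aromatic carbon, para to a hydroxy group and ortho to a phenyl group. The change from compound 2 to compound 4 is bromo in place of chloro on an aromatic carbon and the rest of the structure stays the same.

Within the data shown here, with no measured step as a guide, no shift beyond the scatter is expected in this assay for this swap of one halogen for another. The best starting point is compound 2 at 1160 nM in the absence of closer evidence. The estimate amounts to a 1.1-fold lower number from compound 2 to compound 4 (0.02 log units; within the scatter) as the expected step, and that stays within the scatter. For compound 4 the estimated value is 1100 nM with an expected range of 550 nM to 2200 nM for a repeat measurement.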

Compound 4, half-maximal inhibitory concentration: 740 nM
The estimate for compound 4 lay 1.5-fold (0.17 log units) above the measured number; the measured number falls inside the stated range.
By their numbers in this assay, from the lowest: compounds 1, 3, 4 and 2 (each within the scatter of the next).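

Within the data shown here, this is the first pair here that differs in one place only, so a single change can now be read on its own. In this assay, putting bromo in place of chloro on the aromatic carbon para to a hydroxy group and ortho to a phenyl group gives a 1.6-fold lower number from compound 2 to compound 4 (0.20 log units; within the scatter), a step no larger than repeat measurements of one compound can produce. At this position, and with the rest of this structure, the chloro and bromo compounds therefore cannot be ranked, although this single pair cannot set a rule for the series. No data are available here that would explain this result beyond the assay numbers themselves.

The compounds shown leave open whether a different kind of group on this carbon, such as a methoxy group, a nitrile or an amine, would move the number beyond the scatter. They also leave open whether the same halogen swap would stay as small on the core of compound 1 or compound 3, or with something other than the phenyl group alongside it.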